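The source may hold more compounds than are shown below. What is called first, only, known or untested is meant among the compounds shown, and "the series" means these compounds.

Compound 1 `O=C1NC(O)(CCn2cc(C3=CCCCC3)nn2)C(OCc2ccccc2)=C1OCc1ccccc1`: 70000 nM
Compound 2 `Cc1ccc(-c2cn(C/C=C3\OC(=O)C(OCc4ccccc4)=C3OCc3ccccc3)nn2)cc1`: > 100000 nM
Compound 3 `CCCc1cn(CCC2(O)C(OCc3ccccc3)=C(OCc3ccccc3)C(=O)N2CCC)nn1`: 90000 nM

All three were tested in an ADME assay on HEK293 cells (Homo sapiens) for cytotoxicity, read by MTT assay, with a stated time of 24 h; on this read-out higher numbers stand for weaker inhibition and lower numbers for stronger inhibition. Compound 1 gives 70000 nM and compound 3 gives 90000 nM, and these two values lie within the usual scatter of each other. For compound 2 the assay reports only a limit, > 100000 nM, as recorded in the limit of > 100000 nM in this assay, at which 1 of the 3 values shown sits; compound 2 therefore stands at the edge of the numbers shown, without a number of its own.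

Compound 4 `O=C1O/C(=C\Cn2cc(-c3ccccc3)nn2)C(OCc2ccccc2)=C1OCc1ccccc1` differs from compound 2 by hydrogen in place of methyl on an aromatic carbon. Within the data shown here, no measured pair with this kind of change is available here, so the size of the step cannot be read off from the data. A change this small is not expected to move this assay beyond its scatter in either direction. Compound 4 is therefore estimated at 100000 nM, with a range from 50000 nM to 200000 nM. That estimate is expected to mean a step of a number no higher from compound 2 to compound 4 (the limit leaves the size open), no larger than the scatter, and most likely the assay will again report only a limit.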

Compound 4, half-maximal inhibitory concentration: > 100000 nM
Compound 4 ended at the assay's limit (the forecaster's own chance of this, stated with the estimate: 70%); the middle value lies on the limit itself.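

No step from compound 2 to compound 4 can be read, because both compounds stop at a limit rather than a number: the limit of > 100000 nM in this assay, at which 2 of the 4 values shown sit.

The compounds shown leave open whether swapping 4-methylphenyl for phenyl changes the result in this assay at all.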